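This account rests on a few compounds, and the source may have more. Where it says the series, first, only, none or still open, it means among the compounds named here.

Measured compounds:
Compound 1, `CSc1ccc(OC(C)(C)C2OCC(C/C=C\CCC(=O)O)C(c3cccnc3)O2)c([N+](=O)[O-])c1`: 5000 nM
Compound 2, `Cc1ccc(C#N)c(OC(C)(C)C2OCC(C/C=C\CCC(=O)O)C(c3cccnc3)O2)c1`: a limit only, > 100000 nM
Compound 3, `CC(C)(Oc1ccc(F)cc1)C1OCC(C/C=C\CCC(=O)O)C(c2cccnc2)O1`: 2000 nM

All three share one core and differ only in the aromatic group attached through an oxygen on a saturated carbon. In an assay for inhibition of prostacyclin synthase (Homo sapiens), using microsomes (a lower number here means a stronger inhibitor, a higher number a weaker inhibitor), compound 3 gives the lowest of the two numbers shown; its nearest neighbour is compound 1, and the step of a 2.5-fold lower number from compound 1 to compound 3 (0.40 log units; beyond the scatter) lies beyond the scatter. For compound 2 this assay reports only a limit (the limit of > 100000 nM in this assay, at which 1 of the 3 values shown sits), so the steps of an at least 20-fold higher number from compound 1 to compound 2 (1.30 log units; beyond the scatter) and an at least 50-fold lower number from compound 2 to compound 3 (1.69 log units; beyond the scatter) can only be read as large.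

Compound 4, `CC(C)(Oc1ccccc1F)C1OCC(C/C=C\CCC(=O)O)C(c2cccnc2)O1`, is not yet measured. The change is 2-fluorophenyl in place of 4-fluorophenyl on an oxygen on a saturated carbon; the two compounds have the same atoms, joined differently. Every measured step swaps one aromatic group for a different one at this oxygen, so all three bear on the change, but none of them moves a single fluorine within the same ring. The small change from compound 3 suggests a step no larger than the modest one seen between compound 1 and compound 3, in either direction. Compound 4 is therefore expected to give about 3000 nM in this assay, with a range from 800 nM to 12000 nM. This corresponds to an expected step of a 1.5-fold higher number from compound 3 to compound 4 (0.18 log units; within the scatter).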

Compound 4, half-maximal inhibitory concentration: < 1000 nM
Compound 4: no number, only a limit; the forecaster's own chance of this, stated with the estimate: 5%; middle value at least 3.0-fold (0.47 log units) from the limit.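

For compound 4, this assay gives a limit and not a number: the limit of < 1000 nM in this assay, at which 1 of the 4 values shown sits. Among these compounds, this is the first pair at this oxygen in which the ring stays the same and only the fluorine moves, and the result is an at least 2.0-fold lower number from compound 3 to compound 4 (0.30 log units; that floor lies within the scatter), so the move from 4-fluorophenyl to 2-fluorophenyl gives no sign of weakening inhibition, although the floor of this step is too small to prove a gain. The two other new steps, an at least 100-fold lower number from compound 2 to compound 4 (2.00 log units; beyond the scatter) and an at least 5.0-fold lower number from compound 1 to compound 4 (0.69 log units; beyond the scatter), both lie beyond the scatter, and they show that among the compounds here, a ring carrying a single fluorine gives a lower number in either of the two placements tested than the two rings with larger groups.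

Going by these compounds, how far compound 4 really lies past its limit stays open, and with it the true size of the effect of moving the fluorine. It is also open whether the fluorine is needed at all, since neither plain phenyl nor 2-chlorophenyl at this oxygen is among the compounds shown, and either would help separate the role of the fluorine from that of the ring itself.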